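Benzylamine aryl variation in a bis(trifluoromethyl)benzenesulfonamide series

The source may hold more compounds than are shown below. What is called first, only, known or untested is meant among the compounds shown, and "the series" means these compounds.

Measured so far:
compound 1 `O=S(=O)(NCCCNCc1ccc(Cl)c(C(F)(F)F)c1)c1cc(C(F)(F)F)cc(C(F)(F)F)c1` gives 3500 nM
compound 2 `O=S(=O)(NCCCNCc1ccc(-c2ccccc2)cc1)c1cc(C(F)(F)F)cc(C(F)(F)F)c1` gives 1700 nM

Both values come from a functional assay on MCF7 cells (Homo sapiens) for inhibition, read by MTT assay, with a stated time of 72 h; on this read-out higher numbers stand for weaker inhibition of growth and lower numbers for stronger inhibition of growth. Compound 1 holds the higher of the two numbers; compound 2 sits lower, and the gap between them lies beyond the scatter. Going by the values given here, no single step between measured compounds has been worked out, so the comparison rests on the two values alone.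

Compound 3 `O=S(=O)(NCCCNCc1cccc(Cl)c1)c1cc(C(F)(F)F)cc(C(F)(F)F)c1` has not been measured. It differs from compound 1 by 3-chlorophenyl in place of 4-chloro-3-(trifluoromethyl)phenyl on a saturated chain carbon bound to an amine nitrogen. The shared core and the sulfonamide side are unchanged; only the aryl on the benzylic carbon is exchanged.

With no measured step of this kind in hand, the expectation is conservative. The expected step is a 1.3-fold higher number from compound 1 to compound 3 (0.11 log units; within the scatter), a modest weakening or none beyond the scatter. Compound 3 is therefore estimated at 4500 nM, with a range from 1500 nM to 14000 nM.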

Compound 3, concentration for 50% growth inhibition: 2600 nM
For compound 3 the middle estimate is 1.7-fold (0.24 log units) above the measured one; measured number inside the range.
By their numbers in this assay, from the lowest: compounds 2, 3 and 1 (each within the scatter of the next, the first and the last beyond it).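

In this assay, the first single step read at this position, 3-chlorophenyl in place of 4-chloro-3-(trifluoromethyl)phenyl on a saturated chain carbon bound to an amine nitrogen, gives a 1.3-fold lower number from compound 1 to compound 3 (0.13 log units; within the scatter). The two aryl groups therefore cannot be told apart on this read-out, so the larger substitution pattern of compound 1 shows no measurable advantage over the simpler 3-chlorophenyl of compound 3. No measurement in hand bears on why these two aryl groups read alike.

From the compounds shown here alone, whether the remaining chlorine of compound 3 matters stays open, as an unsubstituted phenyl group would be needed to test it. Also open, going by these compounds, is how a methoxy group or nitrile on this aryl, or a pyridine ring in its place, would read in this assay.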